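This account rests on a few compounds, and the source may have more. Where it says the series, first, only, none or still open, it means among the compounds named here.

Four compounds share the same pattern of testing in a functional assay on K562 cells (Homo sapiens) for antiproliferative activity, read by MTT assay, with a stated time of 72 h; a lower number here means a stronger inhibitor, a higher number a weaker inhibitor. Compound 1 `CCN1C(=O)S/C(=C\C2=Cc3ccccc3OC2)C1=O` sits at a limit of this assay. In this assay compound 1 gives > 200000 nM, which is a limit and not a number. Compound 3 `CCN1C(=O)S/C(=C\C2=Cc3cccc(OC)c3OC2)C1=O` differs from compound 1 by one change, (methoxy in place of hydrogen on an aromatic carbon), and in this assay compound 3 gives 90400 nM. This change made the step of an at least 2.2-fold lower number from compound 1 to compound 3 (0.34 log units; beyond the scatter), and because compound 1 sits at the limit of > 200000 nM in this assay, at which 1 of the 3 values shown sits, only the lower bound of that step is known.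

Compound 2 `O=C(O)CN1C(=O)/C(=C/C2=Cc3ccccc3OC2)SC1=S` is built on a different core; the difference between the two cores is not broken down here. Compound 2 also sits at a limit of this assay. In this assay compound 2 gives > 100000 nM, which is a limit and not a number, as the limit of > 100000 nM in this assay, at which 1 of the 3 values shown sits, records.

Within the data shown here, compound 4 `COc1cccc2c1OCC(/C=C1\SC(=S)N(CC(=O)O)C1=O)=C2` is the not yet measured partner: it carries the change (methoxy in place of hydrogen on an aromatic carbon), the same change in the same place as the one from compound 1 to compound 3. If the change acts alike on the second core, compound 4 is expected to move by a step of an at least 2.0-fold lower number from compound 2 to compound 4 (0.30 log units; that floor lies within the scatter), a step of about the size seen in an at least 2.2-fold lower number from compound 1 to compound 3 (0.34 log units; beyond the scatter), though that earlier step is itself only a lower bound. On that basis the estimate for compound 4 is 50000 nM, expected to fall between 15000 nM and 150000 nM.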

Compound 4, half-maximal inhibitory concentration: > 200000 nM
Compound 4: a limit, no number; the forecaster's own chance of this, stated with the estimate: 35%; middle value at least 4.0-fold (0.60 log units) away from the limit.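

In this assay compound 2 sits at a limit and not at a number: the limit of > 100000 nM in this assay, at which 1 of the 4 values shown sits. Among these compounds, compound 4 also sits at a limit, so no step from compound 2 to compound 4 can be read: the limit of > 200000 nM in this assay, at which 2 of the 4 values shown sit. The compounds shown leave open whether methoxy in place of hydrogen on an aromatic carbon changes the activity on the core of compound 2 at all, and in which direction.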